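Hydrazone series: trifluoromethyl removed from compound 3

The compounds below may be only part of what the source reports. "The series", "measured", "known", "first", "only" and "open" are said of these compounds alone.

Measured compounds in an assay on isolated protein for binding affinity to corticotropin-releasing factor receptor 1 (Homo sapiens); on this read-out higher numbers stand for weaker inhibition and lower numbers for stronger inhibition:
- compound 1, `CC(=O)/C(=N\c1ccccc1Cl)NNc1ccccc1Cl`: > 10000 nM, a limit of the assay
- compound 2, `CC(=O)/C(=N\c1ccccc1)NNc1ccccc1C(F)(F)F`: 2260 nM
- compound 3, `CC(=O)/C(=N\c1ccccc1Cl)NNc1ccccc1C(F)(F)F`: > 10000 nM, a limit of the assay

Compound 3 stands at the upper end of what is shown: its result in this assay is only a limit and not a number, and the limit of > 10000 nM in this assay, at which 2 of the 3 values shown sit, is shared by compound 1 as well. For the measured compounds named here, compound 2 is the only compound of the three with a numerical value.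

Compound 4, `CC(=O)/C(=N\c1ccccc1Cl)NNc1ccccc1`, has not yet been measured. It differs from compound 3 by hydrogen in place of trifluoromethyl on an aromatic carbon.

Going by the values given here, two measured steps touch compound 3. The step that the two limits leave unreadable from compound 1 to compound 3 concerns the same aryl ring as the present change, but both ends sit at the limit, so its size is unreadable. The step of an at least 4.4-fold higher number from compound 2 to compound 3 (0.64 log units; beyond the scatter) concerns the other aryl ring; compound 4 keeps that chloro group, which in compound 3 and compound 1 goes with a limit result.

The change to compound 4 takes away the trifluoromethyl but leaves the chloro that accompanies the weakest results shown, so no clear gain beyond the scatter is expected; the estimated step is a step that the limit leaves unreadable from compound 3 to compound 4. For compound 4 the value in this assay is estimated at 15000 nM, within 4000 nM to 60000 nM, and a limit result is considered likely.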

Compound 4, inhibition constant: > 10000 nM
Compound 4: only a limit was reported; the forecaster's own chance of this, stated with the estimate: 70%; the middle value is on the limit's open side.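

In this assay compound 4 gives > 10000 nM, a limit of the assay. The steps from compound 1 and from compound 3 to compound 4 cannot be read because all three results sit at the same limit: the limit of > 10000 nM in this assay, at which 3 of the 4 values shown sit. Left open is whether hydrogen, chloro or trifluoromethyl at that aromatic carbon makes any difference while the other chloro group stays in place.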